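The compounds below may be only part of what the source reports. "The series", "measured", "known", "first", "only" and "open" are said of these compounds alone.

Compound 1 `CC(=O)c1cc(-c2ccc(F)cc2)cc2cc(-c3ccccc3)[nH]c12` carries a fluoro on one of its outer rings and, in a functional assay on MCF7 cells (Homo sapiens) for cytotoxicity, read by MTT assay, with a stated time of 2 days, tested at 10 uM (a higher number here means a weaker effect of the compound at the concentration tested, a lower number a stronger effect), compound 1 gives 73.8%. Compound 2 `COc1ccc(-c2cc(C(C)=O)c3[nH]c(-c4ccccc4)cc3c2)cc1` differs from it in a single place: methoxy in place of fluoro on an aromatic carbon. In this assay compound 2 gives 49.5%, so this one change produced a number 24.3 percentage points lower from compound 1 to compound 2 (beyond the scatter), a shift that is beyond the usual scatter of the measurement.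

Compound 3 `CC(=O)c1cc(/C=C/c2ccc(F)cc2)cc2cc(-c3ccc(F)cc3)[nH]c12` is built on a different core; the difference between the two cores is not broken down here. In this assay compound 3 gives 67.4%, a number that sits within the scatter of the value of compound 1 and well apart from the value of compound 2.

Compound 4 `COc1ccc(-c2cc3cc(/C=C/c4ccc(F)cc4)cc(C(C)=O)c3[nH]2)cc1` has not yet been measured. It differs from compound 3 in one place: methoxy in place of fluoro on an aromatic carbon. Among the measured compounds shown here, this is the same change, at the same place, as the one that separates compound 1 from compound 2, and across these compounds it appears twice in all. On that basis compound 4 is expected to show a step of about a number 21.4 percentage points lower from compound 3 to compound 4 (beyond the scatter), because the identical change once gave a number 24.3 percentage points lower from compound 1 to compound 2 (beyond the scatter). For the measured compounds named here, with only a single earlier example, and a different core beneath the change, the expectation is held loosely. For compound 4 the expected value in this assay is 46%, with a plausible range from 32% to 62%.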

Compound 4, a percentage reported as activity, at one concentration (the size of the read-out at that concentration, not a potency): 76.5%
For compound 4 the middle estimate is 30.5 percentage points below the measured one; the whole stated range lies below it.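

In this assay, among the compounds shown here, methoxy in place of fluoro gives a number 9.1 percentage points higher from compound 3 to compound 4 (within the scatter), so on the core of compound 3 this change produces no step that can be told apart from the usual variation between repeated measurements. The change therefore does not carry from the core of compound 1 to the core of compound 3 with a constant size, and a step seen on one core is a poor guide to the other: the same change on two cores in this assay, a number 24.3 percentage points lower (beyond the scatter) from compound 1 to compound 2 and a number 9.1 percentage points higher (within the scatter) from compound 3 to compound 4, 33.4 percentage points apart, beyond the scatter of two such steps. This rests on a single pair of compounds for each core, so it does not show which feature of the two cores separates the results, nor whether either step would hold for other compounds built on the same core.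

The compounds shown carry only fluoro or methoxy at this position, which leaves open what an amine, a carboxylic acid or a longer chain such as butoxy would do there on either core. Also open, on these data alone, is whether the two cores would differ in the same way for those groups, and whether the pattern of stronger and weaker effects seen at this single concentration would hold at other concentrations.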